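The source may report more compounds than this note shows. Statements on the series, on what has been measured and on what is new or still open speak of the compounds shown alone.

In a functional assay on SF-268 cells (Homo sapiens) for cytotoxicity, read by MTT assay, with a stated time of 3 days (a higher number here means a weaker inhibitor, a lower number a stronger inhibitor), compound 1 `N#Cc1c(Cl)nc(SCc2nc3ccccc3[nH]2)nc1-c1ccccc1` with chloro on an aromatic carbon gives 3.2 nM in this small series. Compound 2 `N#Cc1c(Nc2ccccc2)nc(SCc2nc3ccccc3[nH]2)nc1-c1ccccc1` with anilino in that place gives 4.46 nM and compound 3 `N#Cc1c(Nc2nccs2)nc(SCc2nc3ccccc3[nH]2)nc1-c1ccccc1` with (1,3-thiazol-2-yl)amino gives 2.55 nM on the same scale. Compound 3 thus lies within the scatter of both others. Compound 4 `N#Cc1c(NNC(N)=S)nc(SCc2nc3ccccc3[nH]2)nc1-c1ccccc1` differs from compound 3 by a group of 4 heavy atoms (1 carbon, 2 nitrogen, 1 sulfur; no ring) in place of a group of 5 heavy atoms (3 carbon, 1 nitrogen, 1 sulfur; one five-membered aromatic ring with 2 hetero atoms), on a nitrogen on an aromatic ring and in no other way. The measured steps that bear on this place are a 1.4-fold higher number from compound 1 to compound 2 (0.14 log units; within the scatter) together with a 1.3-fold lower number from compound 1 to compound 3 (0.10 log units; within the scatter) and a 1.7-fold lower number from compound 2 to compound 3 (0.24 log units; within the scatter) and all of them stay within the scatter. None of these compounds carries the group that enters in compound 4, so the data reach it only by extension. With compound 3 at 2.55 nM and those steps so small, no step beyond the scatter is expected in this assay and no direction can be named. The expected change is a 1.4-fold higher number from compound 3 to compound 4 (0.14 log units; within the scatter) at this estimate. In this assay compound 4 is estimated at 3.5 nM with an expected range of 1.5 nM to 9 nM around that figure.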

Compound 4, half-maximal inhibitory concentration: 3.37 nM
Beside the measured number, compound 4's estimate is 1.0-fold (0.02 log units) above it; low and high end bracket the measured number.
By their numbers in this assay, from the lowest: compounds 3, 1, 4 and 2 (each within the scatter of the next).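

In this assay, for the compounds shown here, the earlier compounds carried only aromatic rings on this nitrogen, and the new compound shows that a group with no ring, with 2 hydrogen-bond donors where 1,3-thiazol-2-yl has 0, also gives a number within the scatter of theirs: a 1.3-fold higher number from compound 3 to compound 4 (0.12 log units; within the scatter) and a 1.3-fold lower number from compound 2 to compound 4 (0.12 log units; within the scatter). The wider exchange of chloro on the aromatic carbon for the whole group of 5 heavy atoms also stays within the scatter, with a 1.1-fold higher number from compound 1 to compound 4 (0.02 log units; within the scatter), so all the compounds shown remain indistinguishable at this place. No measurement shown here offers an explanation for this flat result.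

The compounds shown leave open whether any substituent at this place can move the number beyond the scatter, since none of the steps does so. A plain amino group, a carboxylic acid or a longer alkyl chain could test this.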